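Hydrazone thiazole series: removing a bromo from compound 2

The compounds below may be only part of what the source reports. "The series", "measured", "known", "first", "only" and "open" are said of these compounds alone.

Measured compounds:
compound 1 `COc1cc(/C=N/Nc2nc(-c3ccc(Br)cc3)cs2)cc(Br)c1OC` — > 100000 nM
compound 2 `COc1cc(/C=N/Nc2nc(-c3ccc(C(F)(F)F)cc3)cs2)c(Br)c(Br)c1OC` — > 100000 nM
compound 3 `COc1cc(/C=N/Nc2nc(-c3ccc(Br)cc3)cs2)c(Br)c(Br)c1OC` — > 100000 nM

In an ADME assay on HUVEC cells (Homo sapiens) for inhibition, read by MTT assay, with a stated time of 48 h (on this read-out lower numbers stand for stronger inhibition and higher numbers for weaker inhibition), compound 1 gives only a limit, > 100000 nM. In this assay compound 2 likewise gives only a limit, > 100000 nM. Compound 3 also gives only a limit in this assay, > 100000 nM. Compound 2 therefore stands at the limit, together with the other two values shown, as noted in the limit of > 100000 nM in this assay, at which 3 of the 3 values shown sit.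

The step to compound 4 `COc1cc(/C=N/Nc2nc(-c3ccc(C(F)(F)F)cc3)cs2)cc(Br)c1OC` is hydrogen in place of bromo on an aromatic carbon. Among the measured compounds shown here, two measured steps touch the same region of the core: a step that the two limits leave unreadable from compound 1 to compound 3 and a step that the two limits leave unreadable from compound 2 to compound 3. Both are unreadable in size, since every value sits at the limit, so neither gives a readable direction for the present change. For the measured compounds named here, no measured step has yet produced a number.

The expected step from compound 2 to compound 4 is a step that the limit leaves unreadable from compound 2 to compound 4, with no readable change beyond the scatter expected. Compound 4 is estimated at 150000 nM in this assay, with an expected range from 50000 nM to 500000 nM, most likely reported again as a limit.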

Compound 4, half-maximal inhibitory concentration: > 100000 nM
Compound 4 was reported as a limit (the forecaster's own chance of this, stated with the estimate: 85%); the middle value does not contradict the limit.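

Among the compounds shown here, compound 4 gives only a limit in this assay, as do compound 1, compound 2 and compound 3, so no step among them can be read: the limit of > 100000 nM in this assay, at which 4 of the 4 values shown sit. The compounds shown leave open the size and direction of any effect on inhibition from changing the bromo or trifluoromethyl groups.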